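This account rests on a few compounds, and the source may have more. Where it says the series, first, only, none or still open, it means among the compounds named here.

Measured in a functional assay on MT4 cells (Homo sapiens) for cytotoxicity; on this read-out higher numbers stand for lower toxicity in this test and lower numbers for higher toxicity in this test:
- compound 1 `Cc1cn(C2CC(N=[N+]=[N-])C(COC(=O)NCCCO)O2)c(=O)[nH]c1=O`: > 50000 nM
- compound 2 `Cc1cn(C2CC(N=[N+]=[N-])C(COC(=O)OCCCC(=O)OC(C)(C)C)O2)c(=O)[nH]c1=O`: > 50000 nM
- compound 3 `Cc1cn(C2CC(N=[N+]=[N-])C(COC(=O)OCCCCO)O2)c(=O)[nH]c1=O`: > 50000 nM

Each of these entries is a limit of the assay, not a number. Compound 3 therefore has no numerical position of its own and shares (the limit of > 50000 nM in this assay, at which 3 of the 3 values shown sit).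

Compound 4 `CCCCOC(=O)OCC1OC(n2cc(C)c(=O)[nH]c2=O)CC1N=[N+]=[N-]` is the next structure to place. Its difference from compound 3 is hydrogen in place of hydroxy on a saturated chain carbon, four bonds along the chain from an oxygen next to a carbonyl group. Cut one bond further out, this reads 3-hydroxypropyl to propyl.

Among the compounds with values here, two measured steps bear on this change: a step that the two limits leave unreadable from compound 1 to compound 3 and a step that the two limits leave unreadable from compound 2 to compound 3. Neither gives a size, so neither can be carried over to the new step. The second is the closer of the two, as it also alters the saturated chain. With tert-butoxycarbonyl in place of the hydroxymethyl, compound 2 reports > 50000 nM, which is a limit.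

No direction of change is therefore expected in this assay, and no step beyond the scatter is expected. The estimate corresponds to a number no higher from compound 3 to compound 4 (the limit leaves the size open), an expected step of no clear size. For compound 4 the expected value is 50000 nM, with an estimated range from 20000 nM to 100000 nM.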

Compound 4, half-maximal cytotoxic concentration: > 50000 nM
Compound 4 was reported as a limit; the forecaster's own chance of this, stated with the estimate: 70%; the middle value lies on the limit itself.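

In this assay compound 4 gives > 50000 nM, which is a limit of the assay. No step from compound 1, compound 2 or compound 3 to compound 4 can be read, and the series sits together: the limit of > 50000 nM in this assay, at which 4 of the 4 values shown sit.

The compounds shown leave open whether these side chains on the shared core differ at all in this assay.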